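Fluoro for carboxy on the aniline of compound 2

A few compounds are considered here, and "the series" means these few. Any claim that something is new, unique, unknown or untested is made for them only; others in the source may bear on it.

Of the compounds shown here, three from a shared core have been measured in a functional assay on A549 cells (Homo sapiens) for cytotoxicity, read by sulforhodamine B assay; on this read-out lower numbers stand for stronger inhibition and higher numbers for weaker inhibition. Compound 1 `C=C1[C@@H](C/C=C2/C(=O)OC[C@H]2OC(C)=O)[C@]2(C)CC[C@@H](OC(C)=O)[C@@](C)(CO[Si](C)(C)C(C)(C)C)[C@H]2C[C@@H]1O` gives 6850 nM, compound 3 `C=C1[C@@H](OC(C)=O)C[C@@H]2[C@](C)(CO[Si](C)(C)C(C)(C)C)[C@H](OC(C)=O)CC[C@@]2(C)[C@@H]1C[C@@H](Nc1ccc(C(=O)O)cc1)C1=CCOC1=O` gives 4210 nM, and compound 2 `C=C1[C@@H](OC(C)=O)C[C@@H]2[C@](C)(COC=O)[C@H](OC(C)=O)CC[C@@]2(C)[C@@H]1C[C@@H](Nc1ccccc1C(=O)O)C1=CCOC1=O` gives 45900 nM, the highest of the three numbers, beyond the scatter from both compound 1 and compound 3. Compound 4 `C=C1[C@@H](OC(C)=O)C[C@@H]2[C@](C)(COC=O)[C@H](OC(C)=O)CC[C@@]2(C)[C@@H]1C[C@@H](Nc1ccccc1F)C1=CCOC1=O` differs from compound 2 in one place: fluoro in place of carboxy on an aromatic carbon. Among the compounds with values here, no measured pair shows this change, so its effect is open. In this assay the step from compound 2 to compound 4 is expected to lower the number beyond the scatter, a 3.1-fold lower number from compound 2 to compound 4 (0.49 log units; beyond the scatter), because compound 2 starts from 45900 nM. Compound 4 is therefore estimated at 15000 nM, within a range of 4000 nM to 60000 nM.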

Compound 4, half-maximal inhibitory concentration: 23600 nM
Estimate against measurement, compound 4: 1.6-fold (0.20 log units) below, within the range that was stated.
By their numbers in this assay, from the lowest: compounds 3 and 1 (each within the scatter of the next); then compounds 4 and 2 (each within the scatter of the next).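

In this assay, within the data shown here, fluoro in place of carboxy on this aromatic carbon, ortho to a large group, gives a 1.9-fold lower number from compound 2 to compound 4 (0.29 log units; within the scatter) and so offers the first direct reading of this position. Here the three heavy atoms of carboxy, with its hydrogen-bond donor and acceptor, give way to one fluorine atom without a step that can be told from the scatter. Nothing measured on these compounds offers an explanation for this result.

As far as these compounds go, whether an amine or a methoxy group at this place would also stay within the scatter of compound 2 remains open. So does whether fluoro in place of carboxy would give a similar step on another core.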